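The source may hold more compounds than are shown below. What is called first, only, known or untested is meant among the compounds shown, and "the series" means these compounds.

Working notes on the quinazoline-type series, three compounds measured, one pending.

Compound 1 `Clc1ccc(CNc2ccc3ncnc(Nc4cccc(Br)c4)c3c2)cc1` gives 920 nM in a functional assay on HepG2 cells (Homo sapiens) for antiproliferative activity, read by MTT assay, with a stated time of 48 h; on this read-out higher numbers stand for weaker inhibition and lower numbers for stronger inhibition. Compound 2 `Brc1ccc(CNc2ccc3ncnc(Nc4cccc(Br)c4)c3c2)cc1` gives 1410 nM in this assay. The change between them, (bromo in place of chloro on an aromatic carbon), made a step of a 1.5-fold higher number from compound 1 to compound 2 (0.19 log units; within the scatter).

Compound 3 `Clc1cccc(Nc2ncnc3ccc(NCc4ccccc4Cl)cc23)c1` gives 5330 nM in this assay, the highest number of the three; the difference between its core and that of compound 1 is not broken down here.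

Compound 4 `Clc1cccc(Nc2ncnc3ccc(NCc4ccccc4Br)cc23)c1` is to be measured in this assay. It differs from compound 3 by bromo in place of chloro on an aromatic carbon. This is the same kind of change as from compound 1 to compound 2, but not the same: in the earlier pair the halogen sits para to a large group, here it sits ortho to a large group.

From compound 3 to compound 4 the step is expected to be a 1.3-fold higher number from compound 3 to compound 4 (0.12 log units; within the scatter). This expectation rests on the earlier step of a 1.5-fold higher number from compound 1 to compound 2 (0.19 log units; within the scatter) lying within the scatter, so little movement is anticipated. For compound 4 the estimate is 7000 nM, expected to fall between 3500 nM and 14000 nM.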

Compound 4, half-maximal inhibitory concentration: 4170 nM
For compound 4 the middle estimate is 1.7-fold (0.22 log units) above the measured one; the range from low to high includes it.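

In this assay, bromo in place of chloro ortho to a large group gives a 1.3-fold lower number from compound 3 to compound 4 (0.11 log units; within the scatter), so this swap stays within the scatter on this core as well. Set beside the earlier pair, the two steps show no difference that can be told from the scatter: the same change on two cores in this assay, a 1.5-fold higher number (0.19 log units; within the scatter) from compound 1 to compound 2 and a 1.3-fold lower number (0.11 log units; within the scatter) from compound 3 to compound 4, 2.0-fold (0.29 log units) apart, within the scatter of two such steps. Among the compounds shown here, this supports treating the swap as a change that carries over between these two cores without a readable shift, but it does not show that the opposite directions of the two steps are real, it rests on only two pairs, and those pairs differ in where the halogen sits as well as in the core, so the two cannot be separated.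

The compounds shown leave open how other groups would read in place of the halogen on the benzyl group, such as a methoxy group, a nitrile or an amine. Also open, going by these compounds, is what the halogen on the other aromatic ring contributes on its own, apart from the benzyl halogen.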